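The source may hold more compounds than are shown below. What is called first, only, known or untested is meant among the compounds shown, and "the series" means these compounds.

Going by the values given here, in a functional assay on MCF7 cells (Homo sapiens) for cytotoxicity, read by MTT assay, with a stated time of 72 h (on this read-out higher numbers stand for weaker inhibition and lower numbers for stronger inhibition), compound 2 `O=C(Nc1ccc(Oc2ccnc3[nH]ccc23)cc1)c1cc(-c2ccc(F)cc2)ncn1` gives 15900 nM, the only number measured in this group. Compound 1 `O=C(Nc1ccc(Oc2ccnc3[nH]ccc23)cc1)c1nccc(-c2ccc(F)cc2)n1` appears in this assay only as "not active" (no number reported), with no number attached, so nothing can be compared. Compound 3 `O=C(Nc1ccc(Oc2ccnc3[nH]ccc23)cc1)c1cc(-c2ccc(Br)cc2)ncn1` differs from compound 2 in a single change: bromo in place of fluoro on an aromatic carbon. Among the compounds with values here, no measured pair shows what such a swap does here, so the expected step of a 1.3-fold lower number from compound 2 to compound 3 (0.12 log units; within the scatter) is a small one, not beyond the usual scatter and in no settled direction. Compound 3 is therefore estimated at 12000 nM in this assay, somewhere between 4000 nM and 40000 nM.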

Compound 3, half-maximal inhibitory concentration: 3840 nM
For compound 3 the middle estimate is 3.1-fold (0.49 log units) above the measured one; measured number outside the range, below it.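

Going from 4-fluorophenyl to 4-bromophenyl gives the first readable step at this position: in this assay the change is a 4.1-fold lower number from compound 2 to compound 3 (0.62 log units; beyond the scatter). So the choice of halogen on this aromatic carbon can move the number by more than the usual scatter, even though only one heavy atom is exchanged. No measurement shown here explains the shift.

A single step sets no trend. Going by these compounds, whether chloro, methyl or an amine on the same carbon would give a lower or higher number remains open.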